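Removal of the side-chain hydroxy from compound 1

The compounds below may be only part of what the source reports. "The series", "measured", "known", "first", "only" and "open" are said of these compounds alone.

Compound 1 `O=C1C[C@H]2O[C@H]([C@H](O)c3ccccc3)[C@H](O)[C@H]2O1` sits at a limit in a functional assay on MRC5 cells (Homo sapiens) for antiproliferative activity, read by MTT assay, with a stated time of 72 h; a higher number here means a weaker inhibitor, a lower number a stronger inhibitor: compound 1 gives > 100000 nM, a limit of the assay rather than a number. Compound 2 `O=C1CC[C@@H]([C@@H](O)[C@H](O)[C@H](O)c2ccccc2)O1` likewise gives > 100000 nM in this assay, again a limit. Compound 3 `O=C1C[C@H]2O[C@H]([C@H](OC(=O)c3ccccc3)c3ccccc3)[C@H](O)[C@H]2O1` gives > 100000 nM in this assay, also a limit. For the measured compounds named here, the one step with both ends measured, a step that the two limits leave unreadable from compound 1 to compound 3, has no readable size, as all three values rest at the limit of > 100000 nM in this assay, at which 3 of the 3 values shown sit. Compound 4 `O=C1C[C@H]2O[C@H](Cc3ccccc3)[C@H](O)[C@H]2O1` differs from compound 1 by hydrogen in place of hydroxy on a saturated chain carbon bound to an aromatic carbon and a saturated ring carbon. Going by the values given here, no measured step bears on this change, and the three limits give no direction to it. Compound 4 is therefore expected to stay near the limit, at 150000 nM with a range of 50000 nM to 500000 nM. The expected step that the limit leaves unreadable from compound 1 to compound 4 is accordingly none beyond the scatter.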

Compound 4, half-maximal inhibitory concentration: > 100000 nM
Compound 4: no number, only a limit; the forecaster's own chance of this, stated with the estimate: 85%; the middle value is on the limit's open side.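

The step from compound 1 to compound 4 cannot be read: both values are limits. In this assay the compounds shown leave open which change to the shared core, if any, gives a number rather than a limit.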